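The compounds below may be only part of what the source reports. "The series", "measured", "known", "first", "only" and "open" are said of these compounds alone.

Measured compounds:
compound 1, `Fc1ccc(-n2cc(COc3ccccc3-c3nc4ccccc4s3)nn2)cc1Cl`, 26300 nM in an ADME assay on MCF-10A cells (Homo sapiens) for cytotoxicity, read by MTT assay, with a stated time of 24 h; on this read-out lower numbers stand for stronger inhibition and higher numbers for weaker inhibition
compound 2, `FC(F)(F)Oc1ccc(-c2cc(COc3ccccc3-c3nc4ccccc4s3)on2)cc1`, 43900 nM in this assay

In this assay compound 2 gives the larger of the two numbers, yet its value and that of compound 1 lie within the scatter of each other, so the two cannot be ranked. Compound 3, `COc1ccc(-c2cc(COc3ccccc3-c3nc4ccccc4s3)on2)cc1`, is not yet measured. It differs from compound 2 in one place: methyl in place of trifluoromethyl on an oxygen on an aromatic ring. Within the data shown here, no pair of measured compounds shows this change, so its effect is unknown. For compound 3 a step of a 1.1-fold higher number from compound 2 to compound 3 (0.06 log units; within the scatter) is expected, that is, no change beyond the scatter. The estimate for compound 3 is 50000 nM, within 20000 nM to 130000 nM.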

Compound 3, half-maximal inhibitory concentration: 34100 nM
Beside the measured number, compound 3's estimate is 1.5-fold (0.17 log units) above it; low and high end bracket the measured number.
By their numbers in this assay, from the lowest: compounds 1, 3 and 2 (each within the scatter of the next).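

Among these compounds, on the oxygen on the aromatic ring, methyl in place of trifluoromethyl gives a 1.3-fold lower number from compound 2 to compound 3 (0.11 log units; within the scatter) in this assay and is the first measured step at this position. Losing all three fluorine atoms from this group therefore produces no difference that can be told from the scatter. Nothing measured here bears on why this is so.

Still open, on these data alone, is whether a different group on this oxygen, such as a longer chain like butyl, or an amine in place of the whole methoxy group, would move the number beyond the scatter.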